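This account rests on a few compounds, and the source may have more. Where it says the series, first, only, none or still open, it means among the compounds named here.

In an ADME assay on a cell-free system (plasma, Homo sapiens) for protein binding, read by LC-MS, with a stated time of 5 h, tested at 5 uM, compound 1 (`CNC(=O)c1cc(S(=O)(=O)N2CCS[C@H]2C(=O)O[C@@H](Cc2c(Cl)c[n+]([O-])cc2Cl)c2ccc(OC(F)F)c(OCC3CC3)c2)cn1C`) gives 99.8% while compound 2 (`CN(C)C(=O)c1cccc(S(=O)(=O)N2CSC[C@H]2C(=O)O[C@@H](Cc2c(Cl)c[n+]([O-])cc2Cl)c2ccc(OC(F)F)c(OCC3CC3)c2)c1`) gives 99.8% and compound 3 (`CN(C)C(=O)c1cccc(S(=O)(=O)N2CCCC[C@H]2C(=O)O[C@@H](Cc2c(Cl)c[n+]([O-])cc2Cl)c2ccc(OC(F)F)c(OCC3CC3)c2)c1`) gives 99.9% on the same read-out. Compound 1 stands level with compound 2, and the gap between compound 1 and compound 3 lies within the usual scatter of repeated measurements, so these three cannot be ranked. All three are almost wholly bound, with very little left free.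

Compound 4 (`COc1ccc(S(=O)(=O)N2CCS[C@H]2C(=O)O[C@@H](Cc2c(Cl)c[n+]([O-])cc2Cl)c2ccc(OC(F)F)c(OCC3CC3)c2)cc1OC`) keeps the core of compound 1 and differs in the group on a sulfonyl sulfur (a group of 10 heavy atoms (8 carbon, 2 oxygen; one six-membered aromatic ring of carbon only) in place of a group of 10 heavy atoms (7 carbon, 2 nitrogen, 1 oxygen; one five-membered aromatic ring with 1 hetero atom), on a sulfonyl sulfur). The group that enters is 3,4-dimethoxyphenyl, with one six-membered aromatic ring of carbon only, in place of one five-membered aromatic ring with 1 hetero atom. Among the measured compounds shown here, no measured pair shows what a single change does here, so there is no direct guide to this swap. The best anchor is compound 1 with its 99.8% as a starting point, and no change beyond the scatter is expected. The expected step of no change at the digits printed from compound 1 to compound 4 (within the scatter) is therefore a small one. Compound 4 is estimated at 99.8% with an expected range from 99.5% to 99.95% once it has been through this assay in the laboratory.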

Compound 4, plasma protein binding: 99.6%
For compound 4 the middle estimate is 2.0-fold (0.30 log units) (unbound fraction) below the measured one; the measured number falls inside the stated range.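

Among the compounds shown here, this is the first pair here that differs in one place only, so it gives the first direct reading at this position: in this assay, the swap on the sulfonyl sulfur gives a 2.0-fold higher unbound fraction from compound 1 to compound 4 (0.30 log units; within the scatter). A group with one five-membered aromatic ring with 1 hetero atom and 1 hydrogen-bond donor leaves, and 3,4-dimethoxyphenyl, with one six-membered aromatic ring of carbon only and 0 hydrogen-bond donors, enters, yet the read-out does not separate compound 1 from compound 4, and both remain almost wholly bound. No measurement shown here bears on why these two groups read alike.

On these data alone, a single swap says little about the full range of groups that could sit on this sulfonyl sulfur, so it stays open whether a group carrying a carboxylic acid or an amine would give a step beyond the scatter. As far as these compounds go, it also stays open whether 3,4-dimethoxyphenyl would read the same way in place of the groups on the sulfonyl sulfur of compound 2 and compound 3, whose rings on the sulfonamide nitrogen differ from that of compound 1.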